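A few compounds are considered here, and "the series" means these few. Any claim that something is new, unique, unknown or untested is made for them only; others in the source may bear on it.

Within the data shown here, compound 1 `COc1ccc([C@H]2CC(=O)N(c3cccc(C)c3)C2)cc1OC1CCCC1` is one of the two measured members. In a functional assay on HEK293 cells (Homo sapiens) for cytotoxicity (on this read-out higher numbers stand for lower toxicity in this test and lower numbers for higher toxicity in this test), compound 1 gives only a limit of the assay, > 10000 nM. Compound 2 `COc1ccc([C@H]2CC(=O)N(c3ccccn3)C2)cc1OC1CCCC1` differs from compound 1 by pyridin-2-yl in place of 3-methylphenyl on an amide-type nitrogen in a ring. In this assay compound 2 likewise gives only a limit, > 10000 nM. Among the measured compounds shown here, the step that the two limits leave unreadable from compound 1 to compound 2 therefore cannot be read, and compound 1 stands at the limit together with the only other value shown, as the limit of > 10000 nM in this assay, at which 2 of the 2 values shown sit, records.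

Compound 3 `COc1ccc([C@H]2CC(=O)N(c3cccc(NS(=O)(=O)c4ccccc4Br)c3)C2)cc1OC1CCCC1` is not yet measured. It differs from compound 1 by ((2-bromophenyl)sulfonyl)amino in place of methyl on an aromatic carbon. For the measured compounds named here, no measured step bears directly on this change; the single step available is unreadable, with both of its values sitting at the limit. For compound 3 the expectation is that this assay again reports the limit, so the estimated step is a step that the limit leaves unreadable from compound 1 to compound 3, no change beyond the scatter. The estimate for compound 3 in this assay is 15000 nM, with a range from 4000 nM to 60000 nM.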

Compound 3, half-maximal cytotoxic concentration: > 10000 nM
Compound 3: no number, only a limit; the forecaster's own chance of this, stated with the estimate: 75%; the middle value lies beyond the limit too.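

No step from compound 1 to compound 3 can be read in this assay, as both compounds give only a limit: the limit of > 10000 nM in this assay, at which 3 of the 3 values shown sit.

The compounds shown leave open how far any of them lies beyond that limit, and whether any change on the shared core would yield a readable number in this assay.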